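The compounds below may be only part of what the source reports. "The series", "measured", "known", "first", "only" and "open" are said of these compounds alone.

Compound 2 `COc1ccc(-c2[nH]c3ccc(OC)cc3c2/C=C(\C#N)S(=O)(=O)c2ccccc2)cc1` gives 851 nM in a functional assay on MCF7 cells (Homo sapiens) for inhibition, read by sulforhodamine B assay, with a stated time of 48 h (a higher number here means a weaker inhibitor of growth, a lower number a stronger inhibitor of growth), the higher of the two numbers recorded so far; compound 1 `COc1ccc(-c2[nH]c3ccccc3c2/C=C(\C#N)S(=O)(=O)c2ccccc2)cc1` gives 398 nM. Among the measured compounds shown here, the only measured step, a 2.1-fold higher number from compound 1 to compound 2 (0.33 log units; beyond the scatter), concerns a methoxy at a different place on the shared core, so it bears only loosely on what follows. Compound 3 `COc1ccc2[nH]c(-c3ccccc3)c(/C=C(\C#N)S(=O)(=O)c3ccccc3)c2c1` differs from compound 2 by hydrogen in place of methoxy on an aromatic carbon. For the measured compounds named here, with no measured step covering this position, the expected step of a 1.2-fold lower number from compound 2 to compound 3 (0.08 log units; within the scatter) is small and its direction uncertain. Compound 3 is therefore estimated at 700 nM, within a range from 300 nM to 1700 nM.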

Compound 3, concentration for 50% growth inhibition: 3900 nM
For compound 3 the middle estimate is 5.6-fold (0.75 log units) below the measured one; the measured number lies above the stated range.
By their numbers in this assay, from the lowest: compound 1; then compound 2; then compound 3.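

Replacing the 4-methoxyphenyl with phenyl gives a 4.6-fold higher number from compound 2 to compound 3 (0.66 log units; beyond the scatter) in this assay, so the methoxy at this position goes with stronger growth inhibition. The methoxy on the shared core goes the other way, with a 2.1-fold higher number from compound 1 to compound 2 (0.33 log units; beyond the scatter), so the effect of a methoxy depends on where it sits. No measurement shown accounts for this change. On these data alone, whether an amine, a hydroxyl or an ethoxy at this position would match the methoxy remains open. So does whether the step would be the same without the methoxy on the core.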